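The source may report more compounds than this note shows. Statements on the series, on what has been measured and on what is new or still open speak of the compounds shown alone.

The shared core carries a pyridinylmethyl group joined through a thiourea in compound 1 `Nc1ccccc1NC(=O)c1ccc(NC(=S)NCc2cccnc2)cc1` or through a urea in compound 2 `Nc1ccccc1NC(=O)c1ccc(NC(=O)NCc2cccnc2)cc1`. In an assay on isolated protein for inhibition of Nicotinamide phosphoribosyltransferase (Homo sapiens), read by fluorescence, with stated times of 5 min and 15 min (on this read-out lower numbers stand for stronger inhibition and higher numbers for weaker inhibition), compound 1 gives 116 nM and compound 2 gives 550 nM, so compound 2 stands with the higher of the two numbers, and the gap between them lies beyond the scatter. Compound 3 `Nc1ccccc1NC(=O)c1ccc(NC(=O)/C(Cl)=C(\Cl)c2cccnc2)cc1`, with a dichlorovinyl amide in place of the urea, reaches only a limit of the assay, > 2000 nM. Compound 4 `Nc1ccccc1NC(=O)c1ccc(NC(=O)NCc2ccc(Cl)nc2)cc1` differs from compound 2 by chloro in place of hydrogen on an aromatic carbon. Going by the values given here, no measured step of this kind exists, so a step from compound 2 to compound 4 of a 1.1-fold lower number from compound 2 to compound 4 (0.04 log units; within the scatter) is expected, no farther than the scatter. Compound 4 is thus estimated at 500 nM, within 200 nM to 1200 nM.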

Compound 4, half-maximal inhibitory concentration: > 2000 nM
Compound 4: no number, only a limit; the forecaster's own chance of this, stated with the estimate: 5%; middle value at least 4.0-fold (0.60 log units) from the limit.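

The earlier compounds shown here varied only the linker, and none showed what a substituent on the pyridin-3-yl group does. Going from pyridin-3-yl to 6-chloropyridin-3-yl, next to the ring nitrogen, brings an at least 3.6-fold higher number from compound 2 to compound 4 (0.56 log units; beyond the scatter) in this assay, so this position does not accept chloro without a loss. Compound 4 reaches only a limit, > 2000 nM, and the full size of the step cannot be read because it ends at that limit: the limit of > 2000 nM in this assay, at which 2 of the 4 values shown sit.

The compounds shown leave open whether fluoro, methyl or an amine on the same carbon would cost as much. They also leave open whether chloro would bring a similar loss on the thiourea of compound 1.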